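Imidazoline Exchanged for Pyrrolidinylmethyl on a Shared Core

This account rests on a few compounds, and the source may have more. Where it says the series, first, only, none or still open, it means among the compounds named here.

In an assay (Rattus norvegicus) for binding affinity to prostacyclin receptor (Homo sapiens), read by radioligand binding (on this read-out lower numbers stand for stronger inhibition and higher numbers for weaker inhibition), compound 1 `COc1ccc(Sc2ccc(NC3=NCCN3)cc2)cc1` gives 50.1 nM; 50.1 nM (2 entries) and compound 2 `COc1ccc(Sc2ccc(NC3=NC(C)CN3)cc2)cc1` gives 63.1 nM, two numbers that sit within the scatter of each other. Among the measured compounds shown here, compound 3 `COc1ccc(Sc2ccc(C3=NCCN3)cc2)cc1` gives 316 nM, the highest number of the set, reached by the step of a 5.0-fold higher number from compound 2 to compound 3 (0.70 log units; beyond the scatter), which is the only step beyond the scatter. Compound 4 `COc1ccc(Sc2ccc(CN3CCCC3)cc2)cc1` carries a group of 6 heavy atoms (5 carbon, 1 nitrogen; one five-membered non-aromatic ring with 1 hetero atom) in place of a group of 5 heavy atoms (3 carbon, 2 nitrogen; one five-membered non-aromatic ring with 2 hetero atoms), on an aromatic carbon. For the measured compounds named here, no measured step exchanges one five-membered ring for another of a different kind at this place; the single step from compound 2 to compound 3 shows only that a change here can shift the number by a modest amount. Compound 4 is therefore expected to land near 1000 nM, within 200 nM to 5000 nM. The step of a 3.2-fold higher number from compound 3 to compound 4 (0.50 log units; beyond the scatter) is expected to lie beyond the scatter, toward a weaker number.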

Compound 4, inhibition constant: 10000 nM
Compound 4: the middle estimate sits 10-fold (1.00 log units) below what was measured, and the stated range ends below it.
By their numbers in this assay, from the lowest: compound 2; then compound 3; then compound 4.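

In this assay, among the compounds shown here, the exchange for (pyrrolidin-1-yl)methyl on this aromatic carbon gives a 32-fold higher number from compound 3 to compound 4 (1.50 log units; beyond the scatter) and is a large step, where the only earlier step beyond the scatter was modest. For the compounds shown here, measured against the group of compound 2, the same place shows a 160-fold higher number from compound 2 to compound 4 (2.20 log units; beyond the scatter) in a single exchange, so the choice of group here can move the number far more than the earlier compounds showed. No evidence at hand bears on the reason for this result.

The compounds shown leave open whether the ring or its link to the aromatic carbon accounts for the step. They also leave open whether a piperidin-1-ylmethyl or a dimethylaminomethyl group here would land nearer compound 3 or compound 4.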